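Adding a hydroxy group to compound 3

The source may hold more compounds than are shown below. What is called first, only, known or untested is meant among the compounds shown, and "the series" means these compounds.

Measured in a functional assay on the whole organism (Hindlimb, strain albino) with Mus musculus as the target, in the maximal electroshock model, with a stated time of 0.5 h; a lower number here means that less compound is needed, a higher number that more compound is needed for the effect:
- compound 1 `O=C(/C=C/c1ccc(Cl)cc1)Nc1nc2ccc(Cl)cc2s1`: 204 umol/kg
- compound 2 `O=C(/C=C/c1ccc(O)cc1)Nc1nc2ccc([N+](=O)[O-])cc2s1`: 382 umol/kg
- compound 3 `O=C(/C=C/c1ccccc1)Nc1nc2ccc(Cl)cc2s1`: 425 umol/kg

Compound 3, at 425 umol/kg, shares the upper end of this small set with compound 2, at 382 umol/kg, the two values lying within the scatter of each other. Compound 4 `O=C(/C=C/c1ccc(O)cc1)Nc1nc2ccc(Cl)cc2s1` has not yet been measured. It differs from compound 3 by hydroxy in place of hydrogen on an aromatic carbon, para to a large group, turning phenyl to 4-hydroxyphenyl (hydroxy in place of hydrogen on an aromatic carbon).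

Among the compounds with values here, only one measured step concerns a substituent on this aromatic ring: a 2.1-fold higher number from compound 1 to compound 3 (0.32 log units; beyond the scatter), with hydrogen in place of chloro. Read in reverse, it suggests that a substituent here may lower the number in this assay, but chloro is not hydroxy and a single step is thin evidence. Compound 2 also carries the 4-hydroxyphenyl group and gives 382 umol/kg, but its core differs from that of compound 4, so it offers no direct comparison. A small move toward a lower number is therefore expected, probably not beyond the scatter, with the estimated step being a 1.4-fold lower number from compound 3 to compound 4 (0.15 log units; within the scatter). Compound 4 is expected at 300 umol/kg, within an estimated range of 140 umol/kg to 620 umol/kg.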

Compound 4, dose for half-maximal effect: 322 umol/kg
Compound 4: the middle estimate sits 1.1-fold (0.03 log units) below what was measured; low and high end bracket the measured number.
By their numbers in this assay, from the lowest: compounds 1, 4, 2 and 3 (each within the scatter of the next, the first and the last beyond it).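

In this assay, turning phenyl to 4-hydroxyphenyl gives a 1.3-fold lower number from compound 3 to compound 4 (0.12 log units; within the scatter), so at this para place hydroxy is not separated from hydrogen. Hydroxy in place of chloro at the same place gives a 1.6-fold higher number from compound 1 to compound 4 (0.20 log units; within the scatter), so the hydroxy compound also stays within the scatter of the chloro compound, even though hydrogen and chloro are themselves set apart by a 2.1-fold higher number from compound 1 to compound 3 (0.32 log units; beyond the scatter); hydroxy thus falls in the span between the two, and neither end can be told from it. Within the data shown here, with the 4-hydroxyphenyl group held fixed, the pair also gives the first clean reading of a change on the other aromatic ring, chloro in place of nitro, and a 1.2-fold lower number from compound 2 to compound 4 (0.07 log units; within the scatter) shows no separation there either.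

Nothing on hand explains these small steps or the larger one seen with chloro. From the compounds shown here alone, it remains open whether methoxy, an amine or a carboxylic acid at this para place would move the number beyond the scatter from hydrogen, and whether a group other than chloro or nitro on the other ring would do so.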